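Cyclohexanecarboxamide series: removing the dichlorophenyl arm

A few compounds are considered here, and "the series" means these few. Any claim that something is new, unique, unknown or untested is made for them only; others in the source may bear on it.

Three compounds of the shared core have so far been examined in a functional assay on A-375 cells (Homo sapiens) for antiproliferative activity, read by trypan blue exclusion and crystal violet staining, with a stated time of 72 h; on this read-out higher numbers stand for weaker inhibition and lower numbers for stronger inhibition. Compound 3 `O=C(NC(c1ccc(Cl)cc1Cl)c1ccc2cccnc2c1O)C1CCCCC1` gives 1010 nM in this assay. Compound 1 `CCCCOc1ccnc2c(O)c(CNC(=O)C3CCCCC3)ccc12` gives 540 nM; the gap to compound 3 lies within the scatter, so no order between the two can be read. Compound 2 `CCCCC(=O)NCc1ccc2cccnc2c1O` has "nd" (no result reported) and adds nothing to the comparison. Of the two numbers, compound 3 holds the higher one, though only by a margin inside the scatter.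

Compound 4 `O=C(NCc1ccc2cccnc2c1O)C1CCCCC1` remains to be measured. It differs from compound 3 by hydrogen in place of 2,4-dichlorophenyl on a saturated chain carbon bound to an amide-type nitrogen and an aromatic carbon. Going by the values given here, no measured pair shows this change, so its effect is not fixed by the data. Compound 1 also bears hydrogen on the saturated chain carbon bound to an amide-type nitrogen and an aromatic carbon and gives 540 nM, a value in the same range as compound 3. The step of a 1.2-fold higher number from compound 3 to compound 4 (0.07 log units; within the scatter) is therefore expected to be small and not beyond the scatter. For compound 4 the estimate in this assay is 1200 nM, with a range from 400 nM to 4000 nM.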

Compound 4, half-maximal inhibitory concentration: 910 nM
Compound 4: middle estimate off by 1.3-fold (0.12 log units), on the high side; measured number inside the range.
By their numbers in this assay, from the lowest: compounds 1, 4 and 3 (each within the scatter of the next).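

In this assay, going by these compounds alone, the only measured pair at this position gives a 1.1-fold lower number from compound 3 to compound 4 (0.05 log units; within the scatter): hydrogen in place of 2,4-dichlorophenyl on the saturated chain carbon, an arm of 8 heavy atoms, brings no change that can be read beyond the scatter. On an aromatic carbon, hydrogen in place of butoxy gives a 1.7-fold higher number from compound 1 to compound 4 (0.23 log units; within the scatter), so that change also sets no order between the two compounds. No supporting data bear on either result.

Steps involving compound 2 cannot be read, as it has no reported result. As far as these compounds go, whether an amine or a carboxylic acid on the saturated chain carbon, or a longer chain in place of butoxy on the aromatic carbon, would move the number beyond the scatter remains open.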